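Aryl swap on the ring nitrogen: cytotoxicity working notes

The source may hold more compounds than are shown below. What is called first, only, known or untested is meant among the compounds shown, and "the series" means these compounds.

Compound 1, `Cc1ccccc1-c1nn(C(C)C)cc1CNCCN1CCN(C)CC1`: in an ADME assay on Huh-7 cells (Homo sapiens) for cytotoxicity (on this read-out higher numbers stand for lower toxicity in this test and lower numbers for higher toxicity in this test), compound 1 gives > 20000 nM, a limit of the assay rather than a number.
Compound 2, `Cc1ccccc1-c1nn(-c2ccc(F)cc2F)cc1CNCCN1CCN(C)CC1`: in this assay compound 2 gives > 20000 nM, likewise a limit.

Both measured compounds rest at the same limit, so the step that the two limits leave unreadable from compound 1 to compound 2 cannot be read in either direction, which follows from the limit of > 20000 nM in this assay, at which 2 of the 2 values shown sit. Compound 2 therefore stands at the limit of this assay with no number of its own; it is neither more nor less toxic than compound 1 on what is shown.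

Compound 3, `Cc1ccc(-n2cc(CNCCN3CCN(C)CC3)c(-c3ccccc3C)n2)c(C)c1`, differs from compound 2 by 2,4-dimethylphenyl in place of 2,4-difluorophenyl on an aromatic nitrogen. Within the data shown here, the only measured step touches the same position and is unreadable, so nothing on hand points to a change beyond the scatter. The expectation is that compound 3 again sits at the limit, with the step that the limit leaves unreadable from compound 2 to compound 3 estimated as no readable move. The estimate for compound 3 in this assay is 25000 nM, expected to lie between 8000 nM and 60000 nM.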

Compound 3, half-maximal cytotoxic concentration: > 20000 nM
Compound 3: a limit, no number (the forecaster's own chance of this, stated with the estimate: 70%); the middle value is on the limit's open side.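

In this assay compound 3 gives > 20000 nM as a limit of the assay. No step between compound 1, compound 2 and compound 3 can be read: the limit of > 20000 nM in this assay, at which 3 of the 3 values shown sit.

The compounds shown leave open whether isopropyl, 2,4-difluorophenyl or 2,4-dimethylphenyl on an aromatic nitrogen makes any difference to cytotoxicity.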